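The source may report more compounds than this note shows. Statements on the series, on what has been measured and on what is new or still open speak of the compounds shown alone.

Values in a functional assay on SK-BR-3 cells (Homo sapiens) for antiproliferative activity, read by MTT assay, with a stated time of 72 h; a higher number here means a weaker inhibitor, a lower number a stronger inhibitor:

Compound 1 `C/C=C1/[C@H](O[C@@H]2O[C@H](CO)[C@@H](O)[C@H](O)[C@H]2O)OC=C(C(=O)OC)[C@H]1CC(=O)NCCC`: > 20000 nM
Compound 2 `C=C(C)CCOC(=O)C[C@@H]1C(C(=O)OC)=CO[C@@H](O[C@@H]2O[C@H](COC(C)=O)[C@@H](OC(C)=O)[C@H](OC(C)=O)[C@H]2OC(C)=O)/C1=C/C`: > 15000 nM

Compound 2 stands only as a limit, > 15000 nM, and not as a number. Compound 1 is also a limit, > 20000 nM. Neither compound therefore has an actual half-maximal inhibitory concentration in this assay. Among the compounds with values here, the two also differ in more than one place, so no measured step is available as a guide.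

Compound 3 `C/C=C1/[C@H](O[C@@H]2O[C@H](COC(C)=O)[C@@H](OC(C)=O)[C@H](OC(C)=O)[C@H]2OC(C)=O)OC=C(C(=O)OC)[C@H]1CC(=O)OCCC1CCCCC1` differs from compound 2 in one place: cyclohexyl in place of 1-methylethenyl on a saturated chain carbon, two bonds along the chain from an oxygen next to a carbonyl group. It carries cyclohexyl in place of 1-methylethenyl on a saturated chain carbon, two bonds along the chain from an oxygen next to a carbonyl group. Put another way, 3-methylbut-3-en-1-yl becomes 2-cyclohexylethyl.

No change beyond the usual scatter is expected in this assay, in either direction. This expectation rests on compound 2 alone, with its limit of > 15000 nM. The expected change is a step that the limit leaves unreadable from compound 2 to compound 3. For compound 3 the estimated value is 18000 nM, with an expected range from 7000 nM to 40000 nM.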

Compound 3, half-maximal inhibitory concentration: > 15000 nM
Compound 3: a limit, no number; the forecaster's own chance of this, stated with the estimate: 70%; the middle value does not contradict the limit.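

No step from compound 2 to compound 3 can be read in this assay, because both compounds give a limit and not a number: the limit of > 15000 nM in this assay, at which 2 of the 3 values shown sit.

The compounds shown leave open what half-maximal inhibitory concentration each one has, and so whether cyclohexyl in place of 1-methylethenyl changes activity in this assay at all.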